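Notes on compound 3 and compound 4

The compounds below may be only part of what the source reports. "The series", "measured", "known", "first", "only" and "open" are said of these compounds alone.

Measured in a functional assay on MDA-MB-231 cells (Homo sapiens) for cytotoxicity, read by ELISA, with a stated time of 2 days (a higher number here means a weaker inhibitor, a lower number a stronger inhibitor), for three compounds:
- compound 1 `Oc1ccccc1-c1cc(-c2ccccc2)cc(-c2ccccc2O)n1` gives 37300 nM
- compound 2 `Oc1ccc(-c2cc(-c3ccccc3)cc(-c3cccnc3)n2)cc1` gives 2200 nM
- compound 3 `Oc1ccccc1-c1cc(-c2ccccc2)nc(-c2ccco2)c1` gives 4600 nM

Compound 3 holds the middle of these three numbers, with compound 2 lower and compound 1 higher, both gaps beyond the scatter. Compound 4 `Oc1ccc(-c2cc(-c3ccccc3)nc(-c3ccco3)c2)cc1` carries 4-hydroxyphenyl in place of 2-hydroxyphenyl on an aromatic carbon opposite the ring nitrogen. Within the data shown here, no measured pair isolates this change. Among the measured compounds shown here, compound 2, the only measured compound with a 4-hydroxyphenyl group, gives 2200 nM as its number but differs in other groups too. A small step to a lower number, within the scatter, is therefore expected. The estimated 1.5-fold lower number from compound 3 to compound 4 (0.19 log units; within the scatter) is tentative. In this assay compound 4 is estimated at 3000 nM (expected range 1000 nM to 9000 nM).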

Compound 4, half-maximal inhibitory concentration: 1000 nM
The estimate for compound 4 lay 3.0-fold (0.48 log units) above the measured number; low and high end bracket the measured number.
By their numbers in this assay, from the lowest: compound 4; then compound 2; then compound 3; then compound 1.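

On the aromatic carbon opposite the ring nitrogen, 4-hydroxyphenyl in place of 2-hydroxyphenyl gives a 4.6-fold lower number from compound 3 to compound 4 (0.66 log units; beyond the scatter) in this assay. This is the only matched read on this position, and it shows that the placement of the hydroxyl on this phenyl ring alone moves the number beyond the scatter, with the furan-2-yl and phenyl groups held constant. On these data alone, whether an amine or a carboxylic acid in place of that hydroxyl would keep the number of compound 4 stays open. No supporting data bear on the reason for this step.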